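Benzyl Variation at the Sulfur of a Shared Core

The compounds below may be only part of what the source reports. "The series", "measured", "known", "first", "only" and "open" are said of these compounds alone.

Measured compounds:
compound 1 `Cc1cc(Nc2cc(-c3ccccc3)[nH]n2)n2nc(SCc3c(Cl)cccc3Cl)nc2n1` 3230 nM
compound 2 `Cc1cc(Nc2cc(-c3ccccc3)[nH]n2)n2nc(SCc3ccccc3Br)nc2n1` 3020 nM
compound 3 `Cc1cc(Nc2cc(-c3ccccc3)[nH]n2)n2nc(SCc3nc4ccccc4[nH]3)nc2n1` 2730 nM

Of the compounds shown here, three built on the same core have been tested in a functional assay on MCF7 cells (Homo sapiens) for inhibition, read by MTT assay, with a stated time of 72 h; a lower number here means a stronger inhibitor, a higher number a weaker inhibitor. Compound 1 shows the highest of the three numbers, yet its steps to the others are small: a 1.1-fold lower number from compound 1 to compound 2 (0.03 log units; within the scatter) and a 1.2-fold lower number from compound 1 to compound 3 (0.07 log units; within the scatter). The step between the other two, a 1.1-fold lower number from compound 2 to compound 3 (0.04 log units; within the scatter), is equally small. Within these three, the group on the saturated chain carbon bound to a sulfur has been varied without any change that rises above the scatter.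

Compound 4 `Cc1ccc(CSc2nc3nc(C)cc(Nc4cc(-c5ccccc5)[nH]n4)n3n2)cc1` takes the same route. The difference from compound 1 is 4-methylphenyl in place of 2,6-dichlorophenyl on a saturated chain carbon bound to a sulfur. All three measured steps bear on this change, since each one exchanges the group at the same place, and none of them moved the number beyond the scatter. The expectation for this assay is therefore a step of no size beyond the scatter in either direction, a 1.1-fold lower number from compound 1 to compound 4 (0.03 log units; within the scatter). Compound 4 is expected to give 3000 nM, within a range from 1500 nM to 6000 nM.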

Compound 4, half-maximal inhibitory concentration: 7290 nM
Estimate against measurement, compound 4: 2.4-fold (0.39 log units) below; measured number outside the range, above it.
By their numbers in this assay, from the lowest: compounds 3, 2 and 1 (each within the scatter of the next); then compound 4.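

The position is less indifferent than the first three compounds suggested: 4-methylphenyl on the saturated chain carbon bound to a sulfur gives a 2.3-fold higher number from compound 1 to compound 4 (0.35 log units; beyond the scatter), along with a 2.4-fold higher number from compound 2 to compound 4 (0.38 log units; beyond the scatter) and a 2.7-fold higher number from compound 3 to compound 4 (0.43 log units; beyond the scatter), each modest but beyond the scatter. The change from 2,6-dichlorophenyl to 4-methylphenyl keeps one six-membered aromatic ring of carbon only, with no hydrogen-bond donors or acceptors and no net charge, so these counts do not separate the two groups. Nothing measured here accounts for the higher number.

As far as these compounds go, whether that number goes with the methyl group or with its place on the ring stays open, and a 2-methylphenyl or a 4-chlorophenyl on the same carbon would separate the two. The compounds shown also leave open how a plain phenyl or an aminophenyl would read here.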